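The source may hold more compounds than are shown below. What is called first, only, known or untested is meant among the compounds shown, and "the series" means these compounds.

Two thiol-containing amides were measured in an assay on isolated protein for inhibition of Neprilysin (Oryctolagus cuniculus); on this read-out higher numbers stand for weaker inhibition and lower numbers for stronger inhibition. Compound 1 `O=C(N[C@H](CSCc1ccccc1)C(=O)O)[C@@H](CS)Cc1ccc(Cl)cc1` gives 3 nM in this assay. Compound 2 `Cc1ccc(CSC[C@@H](NC(=O)[C@@H](CS)Cc2ccc(-c3ccccc3)cc2)C(=O)O)cc1` gives 180 nM in this assay, the higher of the two numbers; the gap to compound 1 is far beyond the scatter of repeated measurements, so compound 2 is clearly the weaker inhibitor of the pair.

The step from compound 2 to compound 3 `Cc1ccc(CSC[C@@H](NC(=O)[C@H](CS)Cc2ccc(-c3ccccc3)cc2)C(=O)O)cc1` involves no change of atoms or bonds: the two compounds have the same atoms and bonds and differ only in configuration as drawn: 1 of 2 stereo elements differ; a stereocentre at a saturated chain carbon is drawn S in compound 2 and R in compound 3. The carbon in question is the one that carries the free thiol and the biphenylmethyl side chain. Among the measured compounds shown here, no pair of measured compounds shows what such an inversion does here, so its size cannot be read from the numbers at hand.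

With no measured comparison to lean on, the expectation for compound 3 is that the inverted centre will move the number upward rather than downward, as a step of a 3.3-fold higher number from compound 2 to compound 3 (0.52 log units; beyond the scatter), and the uncertainty around this expectation is wide. Compound 3 is accordingly estimated at 600 nM in this assay, within a range from 120 nM to 3500 nM.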

Compound 3, half-maximal inhibitory concentration: 290 nM
The estimate for compound 3 lay 2.1-fold (0.32 log units) above the measured number; measured number inside the range.
By their numbers in this assay, from the lowest: compound 1; then compounds 2 and 3 (each within the scatter of the next).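

In this assay, inverting the carbon that carries the free thiol and the biphenylmethyl side chain gives a 1.6-fold higher number from compound 2 to compound 3 (0.21 log units; within the scatter), so the two drawn configurations at this position cannot be told apart on this read-out. Among the compounds shown here, this is the first pair in the set that isolates a single stereocentre, and configuration at that carbon is the only structural variable in the comparison: the fact that compounds 2 and 3 differ only in the configuration as drawn. The finding holds for this one pair only, and it does not show that the configuration at this carbon is unimportant across the series.

As far as these compounds go, it remains open whether the inversion would stay this small with the chlorine-bearing aromatic side chain of compound 1, and what inverting the second stereocentre, at the carbon bearing the carboxylic acid, would do. Also open, from the compounds shown here alone, is whether either configuration at the first carbon would give a similar number with a hydroxamic acid in place of the free thiol.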